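The source may report more compounds than this note shows. Statements on the series, on what has been measured and on what is new or still open speak of the compounds shown alone.

Measured so far in a physicochemical assay for lipophilicity, measured as octanol-water partition; on this read-out higher numbers stand for higher lipophilicity and lower numbers for lower lipophilicity:
- compound 1, `CCCCc1c(Cl)cc(N/C=N/OCC)cc1Cl`: 5.6
- compound 2, `CCO/N=C/Nc1cc(Cl)c([S+]([O-])CC)c(Cl)c1`: 2.9
- compound 3, `C#CCc1c(Cl)cc(N/C=N/OC(C)C)cc1Cl`: 3.9

Among these three numbers compound 3 stands second highest in this assay: its value lies above that of compound 2 and below that of compound 1, and both gaps are beyond the usual scatter. Among the compounds with values here, the only single-place step that has been measured is a number 2.70 log units lower from compound 1 to compound 2 (beyond the scatter), where a group of 4 heavy atoms with a sulfur and an oxygen replaces a carbon-only group of the same count on an aromatic carbon.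

Compound 4, `C#CCc1c(Cl)cc(N/C=N/OCc2ccccc2)cc1Cl`, is not yet measured. It differs from compound 3 in one place: benzyl in place of isopropyl on an oxygen. Within the data shown here, this exchange sits on the oxygen of the shared core, not on the aromatic carbon, and it trades a three-carbon group for a seven-carbon group that brings in an aromatic ring, so the one measured step does not match it in kind or direction. Among the measured compounds shown here, with no directly comparable step available, the expectation rests on the count of carbon atoms added: a step of a number 1.20 log units higher from compound 3 to compound 4 (beyond the scatter) upward is expected in this assay, beyond the scatter. For compound 4 the estimated value is 5.1, within a range from 4.6 to 5.6.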

Compound 4, partition coefficient: 4.2
For compound 4 the middle estimate is 0.90 log units above the measured one; measured number below the stated range.
By their numbers in this assay, from the lowest: compound 2; then compounds 3 and 4 (each within the scatter of the next); then compound 1.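

In this assay, benzyl in place of isopropyl on an oxygen gives a number 0.30 log units higher from compound 3 to compound 4 (within the scatter), so compound 3 and compound 4 cannot be told apart on this read-out. Within the data shown here, this is the first view of this oxygen, since the only earlier step, a number 2.70 log units lower from compound 1 to compound 2 (beyond the scatter), lay on an aromatic carbon and was large. Here, by contrast, benzyl with one six-membered aromatic ring takes the place of isopropyl, and the two numbers still stay within the usual scatter, so for this pair the added carbon count does not give a readable step, and nothing available explains this result.

This single pair cannot show whether the same exchange would behave the same way on the core of compound 1 or compound 2, where other groups sit on the aromatic carbon. It also leaves open whether a different group on this oxygen, such as a longer chain like octyl, an amine or a carboxylic acid, would give a step beyond the scatter.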